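Chloro to bromo on the aromatic carbon: working notes

This account rests on a few compounds, and the source may have more. Where it says the series, first, only, none or still open, it means among the compounds named here.

Measured so far:
compound 1 `O=C(/C=C/c1ccc(Cl)cc1)NS(=O)(=O)c1ccc(F)cc1` gives 2 ug/mL
compound 2 `O=C(/C=C/c1ccc(Br)cc1)NS(=O)(=O)c1ccc(F)cc1` gives 1.2 ug/mL
compound 3 `O=C(/C=C/c1ccccc1[N+](=O)[O-])NS(=O)(=O)c1ccc(Cl)cc1` gives 6.6 ug/mL

All three numbers come from a functional assay on B16-F10 cells (Mus musculus) for antiproliferative activity, read by ELISA and MTT assay, with a stated time of 48 h; a lower number here means a stronger inhibitor, a higher number a weaker inhibitor. Compound 1 and compound 2 share one core and differ only by bromo in place of chloro on an aromatic carbon. The step of a 1.7-fold lower number from compound 1 to compound 2 (0.22 log units; within the scatter) is within the scatter, so the two values are treated as indistinguishable here. Compound 3 sits on a different core; the difference between the core of compound 1 and the core of compound 3 is not broken down here. Compound 3 stands at the highest of the three numbers, and its distance from compound 1 and from compound 2 is beyond the scatter in each case.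

Compound 4 `O=C(/C=C/c1ccccc1[N+](=O)[O-])NS(=O)(=O)c1ccc(Br)cc1` is not yet measured. It differs from compound 3 by bromo in place of chloro on an aromatic carbon, the same change as that between compound 1 and compound 2, at a place described in the same words. In this assay, among the compounds with values here, the only measured instance of this change, compound 1 to compound 2, gave a step within the scatter, so the expectation for compound 4 is a number near that of compound 3, because a 1.7-fold lower number from compound 1 to compound 2 (0.22 log units; within the scatter) was small. The expected step is a 1.5-fold lower number from compound 3 to compound 4 (0.17 log units; within the scatter), and a single pair is a thin basis, so the range is kept wide. Compound 4 is estimated at 4.5 ug/mL, with an expected range from 2.2 ug/mL to 9 ug/mL.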

Compound 4, half-maximal inhibitory concentration: 12.6 ug/mL
Beside the measured number, compound 4's estimate is 2.8-fold (0.45 log units) below it, and the stated range ends below it.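

In this assay, the new step is a 1.9-fold higher number from compound 3 to compound 4 (0.28 log units; within the scatter), so this assay does not tell compound 3 and compound 4 apart. Set against the earlier step, each step taken alone stays within the scatter, yet the gap between the two does not: the same change on two cores in this assay, a 1.7-fold lower number (0.22 log units; within the scatter) from compound 1 to compound 2 and a 1.9-fold higher number (0.28 log units; within the scatter) from compound 3 to compound 4, 3.2-fold (0.50 log units) apart, beyond the scatter of two such steps. Within the data shown here, this shows that the size of the step on the core of compound 1 did not carry over unchanged to the core of compound 3, but with only two pairs it gives no reason for the gap and no rule for any further core, and the differences between the two cores are not broken down here.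

The compounds shown leave open how an iodo group or a methoxy group would read at the same place on either core, which would show whether the gap is confined to the chloro and bromo pairs. They also leave open whether an amine or a carboxylic acid in place of the nitro group on the core of compound 3 would alter the step from chloro to bromo on that core.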